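Acetoxy in place of benzamido: working notes

A few compounds are considered here, and "the series" means these few. Any claim that something is new, unique, unknown or untested is made for them only; others in the source may bear on it.

Measured in an ADME assay on cells (Hepatocyte, Homo sapiens) for metabolic stability, with a stated time of 30 min (a higher number here means that more of the compound is left, a lower number that less of the compound is left), so far:
- compound 1 `O=c1cc(N2CCN(CC3CCC(NS(=O)(=O)c4ccccc4)CC3)CC2)sc2c([N+](=O)[O-])cc(C(F)(F)F)cc12` at 90.8%
- compound 2 `O=C(NC1CCC(CN2CCN(c3cc(=O)c4cc(C(F)(F)F)cc([N+](=O)[O-])c4s3)CC2)CC1)c1ccccc1` at 92.9%

Compound 2 at 92.9% lies within the scatter of compound 1, so the two cannot be separated. The next change leads to compound 3 `CC(=O)OC1CCC(CN2CCN(c3cc(=O)c4cc(C(F)(F)F)cc([N+](=O)[O-])c4s3)CC2)CC1` and puts acetoxy in place of benzamido on a saturated ring carbon. Among the compounds with values here, with benzoyl in place of phenylsulfonyl on an amine nitrogen, the one measured step is a number 2.1 percentage points higher from compound 1 to compound 2 (within the scatter) and it stays small. That step keeps the amine nitrogen and the aromatic ring, whereas this change removes both, so it offers only weak guidance. A lower number is expected in this assay with wide uncertainty, the expected step being a number 20.9 percentage points lower from compound 2 to compound 3 (beyond the scatter) here. Compound 3 is estimated at 72% (expected range 40% to 93%).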

Compound 3, percent of the compound remaining: 0%
The estimate for compound 3 lay 72 percentage points above the measured number, outside the stated range (below it).
By their numbers in this assay, from the lowest: compound 3; then compounds 1 and 2 (each within the scatter of the next).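

In this assay, acetoxy in place of benzamido gives a number 92.9 percentage points lower from compound 2 to compound 3 (beyond the scatter) and acetoxy in place of (phenylsulfonyl)amino gives a number 90.8 percentage points lower from compound 1 to compound 3 (beyond the scatter) on the same saturated ring carbon. This position therefore does not accept every group: the two nitrogen-linked groups cannot be separated in this read-out, while acetoxy stands far apart from both. No measurement available here explains the loss. From the compounds shown here alone, whether it follows the oxygen link or the missing aromatic ring stays open. Acetamido or a plain hydroxyl group on this ring carbon would help separate the two.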